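Working notes: benzyl for chlorophenylcarbonyl, compound 3 expectation

The source may report more compounds than this note shows. Statements on the series, on what has been measured and on what is new or still open speak of the compounds shown alone.

Measured so far:
Compound 1 `O=C1COCCN1c1ccc(/N=C\c2cn(C(=O)c3ccccc3)c3ccccc23)cc1` gives 52.9% in an ADME assay on BV-2 cells (Mus musculus) for cytotoxicity, read by MTT assay, with a stated time of 48 h, tested at 100 uM; a higher number here means a weaker effect of the compound at the concentration tested, a lower number a stronger effect.
Compound 2 `O=C1COCCN1c1ccc(/N=C\c2cn(C(=O)c3ccc(Cl)cc3)c3ccccc23)cc1` gives 80.5% in this assay.

Compound 2 stands highest of the two numbers in this assay; compound 1 is the nearest and only neighbour. Among the compounds with values here, the single measured step is a number 27.6 percentage points higher from compound 1 to compound 2 (beyond the scatter), a modest rise beyond the scatter.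

Compound 3 `O=C1COCCN1c1ccc(/N=C\c2cn(Cc3ccccc3)c3ccccc23)cc1` differs from compound 2 as follows: benzyl in place of (4-chlorophenyl)carbonyl on an aromatic nitrogen. The measured step bears on this only in part: it covers the chloro, which leaves again in compound 3, but not the carbonyl, which also leaves, and not the benzyl, which enters. Because compound 2 sits higher than compound 1 by a number 27.6 percentage points higher from compound 1 to compound 2 (beyond the scatter) and compound 3 no longer carries the chloro, a step downward in this assay is expected, back toward the region of compound 1; the further change at the same position is uncovered, so the range is kept wide. The expected step is a number 22.5 percentage points lower from compound 2 to compound 3 (beyond the scatter). For compound 3 the estimate in this assay is 58%, with a range from 38% to 82%.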

Compound 3, a percentage reported as activity, at one concentration (the size of the read-out at that concentration, not a potency): 56.2%
The estimate for compound 3 lay 1.8 percentage points above the measured number, and the stated range covers the measured number.
By their numbers in this assay, from the lowest: compounds 1 and 3 (each within the scatter of the next); then compound 2.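

The aromatic nitrogen now carries a second kind of change: in this assay benzyl in place of (4-chlorophenyl)carbonyl gives a number 24.3 percentage points lower from compound 2 to compound 3 (beyond the scatter) and so gives up the higher number seen with the chloro-bearing group. Benzyl in place of benzoyl on the same nitrogen gives a number 3.3 percentage points higher from compound 1 to compound 3 (within the scatter) in this assay and so, between the two compounds without chloro, the exchange of the carbonyl-linked group for the benzyl leaves no difference that can be read. Of the three compounds only compound 2 stands apart, and it is also the only one that carries chloro, while the presence or absence of the carbonyl does not separate compound 1 from compound 3 in this read-out.

On these data alone, whether chloro on the benzyl ring would raise the number as it does on the benzoyl ring stays open, as does what a bromo or methoxy group in its place, or a longer alkyl chain or an amine-bearing chain on the nitrogen, would give. The cause of either step also stays open, with no measurement at hand that bears on it.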